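Removing the bromo group from compound 2

A few compounds are considered here, and "the series" means these few. Any claim that something is new, unique, unknown or untested is made for them only; others in the source may bear on it.

- compound 1 `O=C(O)CN1C(=O)/C(=C/c2nc3ccccc3n2Cc2ccc(Br)cc2)SC1=S` gives 8490 nM
- compound 2 `O=C(O)CN1C(=O)/C(=C/c2nc3ccccc3n2Cc2ccc(Br)cc2F)SC1=S` gives 21100 nM
- compound 3 `Cc1ccc(Cn2c(/C=C3\SC(=S)N(CC(=O)O)C3=O)nc3ccccc32)cc1` gives 2640 nM

All three values come from a functional assay on PC-3 cells (Homo sapiens) for cytotoxicity, read by MTT assay, with a stated time of 48 h (on this read-out higher numbers stand for weaker inhibition and lower numbers for stronger inhibition), and compound 2, at 21100 nM here, has the highest number of the three. Compound 4 `O=C(O)CN1C(=O)/C(=C/c2nc3ccccc3n2Cc2ccccc2F)SC1=S` is compound 2 with a single change, hydrogen in place of bromo on an aromatic carbon and the fluoro group stays where it is.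

For the measured compounds named here, no measured pair shows this exact swap, and no measured compound carries hydrogen at that place, so the evidence is indirect. Two measured steps take the bromo group away, and both are modest: a 3.2-fold lower number from compound 1 to compound 3 (0.51 log units; beyond the scatter) when methyl replaces it, and an 8.0-fold lower number from compound 2 to compound 3 (0.90 log units; beyond the scatter) when methyl replaces it and the fluoro group goes too. A third step, a 2.5-fold higher number from compound 1 to compound 2 (0.40 log units; beyond the scatter) when fluoro is added, suggests that part of the larger drop belongs to the fluoro group, which compound 4 keeps. Hydrogen is not methyl, so these steps are only a rough guide. A modest step towards a lower number is therefore expected in this assay with real doubt about its size. The estimate amounts to a 2.2-fold lower number from compound 2 to compound 4 (0.35 log units; beyond the scatter) as the expected change. For compound 4 the expected value is 9500 nM with 3500 nM to 25000 nM as the estimated range.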

Compound 4, half-maximal inhibitory concentration: 1860 nM
The estimate for compound 4 lay 5.1-fold (0.71 log units) above the measured number; measured number below the stated range.
By their numbers in this assay, from the lowest: compounds 4 and 3 (each within the scatter of the next); then compound 1; then compound 2.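

In this assay, for the compounds shown here, replacing the bromo group with hydrogen on the carbon para to a large group, with the fluoro group kept, gives an 11-fold lower number from compound 2 to compound 4 (1.05 log units; beyond the scatter), the only step in this set printed as large, so this bromo group weighs more heavily on the number than the earlier steps suggested. Compound 4 also shows that a fluoro group on the ring does not in itself go with a high number: the swap of 4-bromophenyl for 2-fluorophenyl gives a 4.6-fold lower number from compound 1 to compound 4 (0.66 log units; beyond the scatter), while the swap of 4-methylphenyl for 2-fluorophenyl gives a 1.4-fold lower number from compound 3 to compound 4 (0.15 log units; within the scatter), which is within the scatter, so compound 3 and compound 4 cannot be told apart here. Nothing available explains why removing the bromo group matters so much.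

Going by these compounds alone, the fluoro group's own share stays open, since its one measured step, from compound 1 to compound 2, has the bromo group present, and no ring here carries hydrogen at both places. From the compounds shown here alone, it is also open how chloro, methoxy or an amine on that same carbon would compare with bromo, methyl and hydrogen.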